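Exchanging one five-membered ring on compound 3

The source may hold more compounds than are shown below. What is called first, only, known or untested is meant among the compounds shown, and "the series" means these compounds.

Compound 1 `COCCOc1ccc2c(c1)C=CN(C)C(=O)[C@@H]2C` gives >= 128 ug/mL
Compound 2 `C[C@H]1C(=O)N(C)C=Cc2cc(CC3CCOCC3)ccc21` gives >= 111 ug/mL
Compound 3 `CCOc1ccc2c(c1)C(c1cn[nH]c1)=CN(C)C(=O)[C@@H]2C` gives >= 115 ug/mL

Each of these entries is a limit, not a number. In a physicochemical assay for solubility (on this read-out lower numbers stand for lower solubility and higher numbers for higher solubility), compound 3 has only the limit >= 115 ug/mL. Compound 4 `CCOc1ccc2c(c1)C(c1cn(C)cn1)=CN(C)C(=O)[C@@H]2C` carries 1-methyl-1H-imidazol-4-yl in place of 1H-pyrazol-4-yl on a double-bonded ring carbon. Among the measured compounds shown here, the only measured step, a step that the two limits leave unreadable from compound 1 to compound 2, concerns a different group on an aromatic carbon, and its size cannot be read, so it offers no guide. For the measured compounds named here, with no measured step to suggest a shift, the expected change, a step that the limit leaves unreadable from compound 3 to compound 4, is none beyond the usual scatter in this assay. For compound 4 the estimate is 120 ug/mL, with an expected range of 60 ug/mL to 180 ug/mL.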

Compound 4, solubility: 117 ug/mL
The estimate for compound 4 lay 1.0-fold (0.01 log units) above the measured number; measured number inside the range.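

Among the compounds shown here, compound 3 has only a limit, >= 115 ug/mL, in this assay, so no step from it to compound 4 can be read. The compounds shown leave open whether 1-methyl-1H-imidazol-4-yl in place of 1H-pyrazol-4-yl shifts the read-out of this assay at all.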